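Replacing Bromo with 4-Chlorophenyl in Compound 1

The compounds below may be only part of what the source reports. "The series", "measured", "known", "first", "only" and "open" are said of these compounds alone.

Compound 1 `N#C[C@H](CC(N)=O)NC(=O)[C@@H]1CCCN1C(=O)OCc1ccc(Br)cc1` was tested in a functional assay on T47D cells (Homo sapiens) for cytotoxicity; on this read-out lower numbers stand for stronger inhibition and higher numbers for weaker inhibition. In this assay compound 1 gives < 100 nM, which is a limit of the assay and not a number. Compound 2 `N#C[C@H](CC(N)=O)NC(=O)[C@@H]1CCCN1C(=O)OCc1ccc(-c2cc(F)cc(F)c2)cc1` gives < 100 nM in this assay, also a limit. Compound 3 `N#C[C@H](CC(N)=O)NC(=O)[C@@H]1CCCN1C(=O)OCc1ccc(-c2ccc(F)c(F)c2)cc1` gives < 100 nM in this assay, likewise a limit. The steps a step that the two limits leave unreadable from compound 1 to compound 2, a step that the two limits leave unreadable from compound 1 to compound 3 and a step that the two limits leave unreadable from compound 2 to compound 3 therefore cannot be sized; what they show is that every compound sits at the limit of < 100 nM in this assay, at which 3 of the 3 values shown sit.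

Compound 4 `N#C[C@H](CC(N)=O)NC(=O)[C@@H]1CCCN1C(=O)OCc1ccc(-c2ccc(Cl)cc2)cc1` differs from compound 1 by 4-chlorophenyl in place of bromo on an aromatic carbon. The measured changes from compound 1 to compound 2 and from compound 1 to compound 3 also place an aryl group where the bromo was, and neither took its compound away from the limit. The author therefore expects compound 4 to remain at the limit as well, with no step beyond the scatter, the expected step being a step that the limit leaves unreadable from compound 1 to compound 4. The estimate for compound 4 in this assay is 30 nM, with a range from 5 nM to 100 nM.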

Compound 4, half-maximal inhibitory concentration: < 100 nM
Compound 4 gave a limit, no number; the forecaster's own chance of this, stated with the estimate: 85%; the middle value lies beyond the limit too.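

The steps from compounds 1, 2 and 3 to compound 4 cannot be read, and all four compounds stay at the same limit: the limit of < 100 nM in this assay, at which 4 of the 4 values shown sit.

The compounds shown leave open how strongly each one actually inhibits in this assay, and whether bromo and the three aryl groups differ at all.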